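Series notes: aryl replacement toward compound 4

A few compounds are considered here, and "the series" means these few. Any claim that something is new, unique, unknown or untested is made for them only; others in the source may bear on it.

Three measured compounds share one core and differ only in the aryl group on a nitrogen on an aromatic ring. Compound 1 `CC(C)c1ccc(-c2nc(SCc3cn(CC(=O)NC(=O)Nc4ccccn4)nn3)nc(Nc3ccc(Cl)cc3)c2C#N)cc1` carries 4-chlorophenyl there; in a functional assay on ECa-109 cells (Homo sapiens) for inhibition, read by MTT assay, with a stated time of 72 h (a lower number here means a stronger inhibitor, a higher number a weaker inhibitor), compound 1 gives 11200 nM. Compound 2 `CC(C)c1ccc(-c2nc(SCc3cn(CC(=O)NC(=O)Nc4ccccn4)nn3)nc(Nc3cccc(C(F)(F)F)c3)c2C#N)cc1` carries 3-(trifluoromethyl)phenyl, and in this assay compound 2 gives 24200 nM. Compound 3 `CC(C)c1ccc(-c2nc(SCc3cn(CC(=O)NC(=O)Nc4ccccn4)nn3)nc(Nc3cccc([N+](=O)[O-])c3)c2C#N)cc1` carries 3-nitrophenyl, and in this assay compound 3 gives 31300 nM, the highest of the three numbers; its gap to compound 2 stays within the scatter, its gap to compound 1 does not.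

Going by the values given here, the steps so far: a 2.2-fold higher number from compound 1 to compound 2 (0.33 log units; beyond the scatter), a 2.8-fold higher number from compound 1 to compound 3 (0.45 log units; beyond the scatter) and a 1.3-fold higher number from compound 2 to compound 3 (0.11 log units; within the scatter). Exchanging one aryl for another on this nitrogen has moved the number by modest amounts at most.

Compound 4 `COc1ccccc1Nc1nc(SCc2cn(CC(=O)NC(=O)Nc3ccccn3)nn2)nc(-c2ccc(C(C)C)cc2)c1C#N` is the next step from compound 3: 2-methoxyphenyl in place of 3-nitrophenyl on a nitrogen on an aromatic ring. Among the compounds with values here, no measured pair covers 2-methoxyphenyl, so the three steps above are the only guide; they all concern the same position and span a narrow range. The number for compound 4 is therefore expected to shift only a little, most likely a 1.7-fold lower number from compound 3 to compound 4 (0.24 log units; within the scatter), or not beyond the scatter. In this assay compound 4 is estimated at 18000 nM, with a range of 7000 nM to 45000 nM.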

Compound 4, half-maximal inhibitory concentration: 8960 nM
Compound 4: middle estimate off by 2.0-fold (0.30 log units), on the high side; the measured number falls inside the stated range.
By their numbers in this assay, from the lowest: compounds 4 and 1 (each within the scatter of the next); then compounds 2 and 3 (each within the scatter of the next).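

In this assay, the two aryl groups bearing a substituent at the 3-position now stand apart from 2-methoxyphenyl, with a 3.5-fold lower number from compound 3 to compound 4 (0.54 log units; beyond the scatter) and a 2.7-fold lower number from compound 2 to compound 4 (0.43 log units; beyond the scatter), while a 1.3-fold lower number from compound 1 to compound 4 (0.10 log units; within the scatter) stays within the scatter. The four compounds therefore form two pairs on this nitrogen, with compound 1 and compound 4 at the lower numbers and compound 2 and compound 3 at the higher, so the level of compound 1 is not unique to 4-chlorophenyl and is shared by an aryl group with a different substituent at a different ring position. Nothing shown here accounts for this split into pairs.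

Substituent identity and ring position change together in every step, so it remains open which of the two tracks the split; 3-methoxyphenyl and 4-nitrophenyl on this nitrogen would pull them apart. Also open, as far as these compounds go, is whether any substituent is needed at all, which unsubstituted phenyl would address, and whether an aryl group is needed, which cyclohexyl in its place would address.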